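Methoxy for methyl on the benzyl group

The source may report more compounds than this note shows. Statements on the series, on what has been measured and on what is new or still open speak of the compounds shown alone.

Measured so far in a functional assay on MDA-MB-231 cells (Homo sapiens) for inhibition, read by CCK-8 assay, with a stated time of 48 h; a higher number here means a weaker inhibitor of growth, a lower number a stronger inhibitor of growth
compound 1 `CN1CCN(c2ccc(Nc3ncc(Cl)c(Nc4ccccc4)n3)nc2)CC1` gives 37400 nM
compound 2 `Cc1ccc(CNc2nc(Nc3ccc(N4CCN(C)CC4)cn3)ncc2Cl)cc1` gives 18600 nM

For the measured compounds named here, only one measured step exists, a 2.0-fold lower number from compound 1 to compound 2 (0.30 log units; within the scatter) with 4-methylbenzyl in place of phenyl on a nitrogen on an aromatic ring. Going by the values given here, compound 2 therefore stands within the scatter of compound 1, the only other number available.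

Compound 3 (`COc1ccc(CNc2nc(Nc3ccc(N4CCN(C)CC4)cn3)ncc2Cl)cc1`) carries methoxy in place of methyl on an aromatic carbon, para to a large group (methoxy in place of methyl on an aromatic carbon), which turns 4-methylbenzyl into 4-methoxybenzyl. Among the compounds with values here, the measured step replaced the whole group on that nitrogen, so it bears on this change only loosely, and no measured step covers this substituent alone. No step beyond the scatter is expected in this assay and no direction is favoured. The expected change is small (a 1.0-fold lower number from compound 2 to compound 3 (0.01 log units; within the scatter)). For compound 3 the expected value is 18000 nM (estimated range 8000 nM to 40000 nM).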

Compound 3, concentration for 50% growth inhibition: 14900 nM
For compound 3 the middle estimate is 1.2-fold (0.08 log units) above the measured one; the measured number falls inside the stated range.
By their numbers in this assay, from the lowest: compounds 3, 2 and 1 (each within the scatter of the next, the first and the last beyond it).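

In this assay, methoxy in place of methyl on the aromatic carbon, para to a large group, gives a 1.2-fold lower number from compound 2 to compound 3 (0.10 log units; within the scatter), so this substituent change, now read on its own, does not separate the two 4-substituted benzyl compounds. For the compounds shown here, replacing the whole group on the nitrogen now gives a 2.5-fold lower number from compound 1 to compound 3 (0.40 log units; beyond the scatter), the first step beyond the scatter, though only a modest one. Nothing available explains either step.

From the compounds shown here alone, whether an amine or a carboxylic acid at this position on the benzyl ring would move the number beyond the scatter of compound 2 remains open. Also open, going by these compounds, is how a longer chain in place of the benzyl group on that nitrogen would read in this assay.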